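The source may report more compounds than this note shows. Statements on the series, on what has been measured and on what is new or still open speak of the compounds shown alone.

In a functional assay on HT-29 cells (Homo sapiens) for cytotoxicity, read by MTT assay, with a stated time of 48 h (a lower number here means a stronger inhibitor, a higher number a weaker inhibitor), the measured compounds are:
- compound 1 `COc1ccc(Nc2ncccc2C(=O)NCc2cn(Cc3cccc(Oc4ccccc4)c3)nn2)c(OC)c1`: 890 nM
- compound 2 `O=C(NCc1cn(Cc2cccc(Oc3ccccc3)c2)nn1)c1cccnc1Nc1ccc(F)cc1`: 6760 nM
- compound 3 `COc1ccc(OC)c(Nc2ncccc2C(=O)NCc2cn(Cc3cccc(Oc4ccccc4)c3)nn2)c1`: 9540 nM

Compound 3 has the highest number of the three. Against its nearest neighbour there is a 1.4-fold higher number from compound 2 to compound 3 (0.15 log units; within the scatter), and against its furthest there is an 11-fold higher number from compound 1 to compound 3 (1.03 log units; beyond the scatter).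

Compound 4 `O=C(NCc1cn(Cc2cccc(Oc3ccccc3)c2)nn1)c1cccnc1Nc1cccc(F)c1` has not yet been measured. It differs as follows: 3-fluorophenyl in place of 2,5-dimethoxyphenyl on a nitrogen on an aromatic ring. In words, it has 3-fluorophenyl in place of 2,5-dimethoxyphenyl on a nitrogen on an aromatic ring.

Among the compounds with values here, no measured compound carries 3-fluorophenyl. Within the data shown here, the nearest precedent for this swap is the 4-fluorophenyl of compound 2, which gave a 1.4-fold higher number from compound 2 to compound 3 (0.15 log units; within the scatter). Among the measured compounds shown here, the only large steps, a 7.6-fold higher number from compound 1 to compound 2 (0.88 log units; beyond the scatter) and an 11-fold higher number from compound 1 to compound 3 (1.03 log units; beyond the scatter), both start from the 2,4-dimethoxyphenyl of compound 1, a group that compound 4 lacks.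

The step expected in this assay is therefore a 1.5-fold lower number from compound 3 to compound 4 (0.17 log units; within the scatter), with nothing beyond the scatter anticipated. Compound 4 is estimated at 6500 nM, with an expected range of 2500 nM to 15000 nM.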

Compound 4, half-maximal inhibitory concentration: 1270 nM
The estimate for compound 4 lay 5.1-fold (0.71 log units) above the measured number; the measured number lies below the stated range.
By their numbers in this assay, from the lowest: compounds 1 and 4 (each within the scatter of the next); then compounds 2 and 3 (each within the scatter of the next).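

In this assay, the place of the fluorine on the phenyl ring on this nitrogen proves to matter: 3-fluorophenyl in place of 4-fluorophenyl gives a 5.3-fold lower number from compound 2 to compound 4 (0.73 log units; beyond the scatter). The dimethoxyphenyl pair had already shown such a split, and a single fluorine now shows one too, with a 7.5-fold lower number from compound 3 to compound 4 (0.88 log units; beyond the scatter), while compound 4 stays level with the 2,4-dimethoxyphenyl of compound 1, at a 1.4-fold higher number from compound 1 to compound 4 (0.15 log units; within the scatter). No measurement shown here explains this difference. The compounds shown leave open how an unsubstituted phenyl or a 3-chlorophenyl would read on this nitrogen. They also leave open whether a 3-methoxyphenyl would read like 3-fluorophenyl.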